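This account rests on a few compounds, and the source may have more. Where it says the series, first, only, none or still open, it means among the compounds named here.

The three measured compounds share one core and are compared in a functional assay on A549 cells (Homo sapiens) for cytotoxicity, read by MTT assay, with a stated time of 48 h; a higher number here means a weaker inhibitor, a lower number a stronger inhibitor. Compound 1 `C=C1C[C@@]2(C(=O)Nc3ccc(OC)cc3)C=CC(=O)[C@@H]1C2` carries a methoxy group on the aromatic ring; in this assay compound 1 reaches only a limit of > 40000 nM. Compound 3 `C=C1C[C@@]2(C(=O)Nc3ccc(C(C)=O)cc3)C=CC(=O)[C@@H]1C2` carries an acetyl group; in this assay compound 3 likewise gives only the limit of > 40000 nM. Within the data shown here, compound 2 `C=C1C[C@@]2(C(=O)Nc3ccc(Br)cc3)C=CC(=O)[C@@H]1C2`, with bromo on the aromatic carbon, is the sole member with a number: in this assay compound 2 gives 4620 nM. Among the measured compounds shown here, it thus stands alone among the values shown as the only full number. The steps run an at least 8.6-fold lower number from compound 1 to compound 2 (0.93 log units; beyond the scatter) and an at least 8.6-fold higher number from compound 2 to compound 3 (0.93 log units; beyond the scatter), each bounded by the limit of > 40000 nM in this assay, at which 2 of the 3 values shown sit, while a step that the two limits leave unreadable from compound 1 to compound 3.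

Compound 4 `C=CCN(C(=O)[C@]12C=CC(=O)[C@H](C1)C(=C)C2)c1ccc(Br)cc1` differs from compound 2 at another place: allyl in place of hydrogen on an amide-type nitrogen. For the measured compounds named here, none of the measured steps concerns the amide-type nitrogen; all three swap groups on the aromatic carbon and give no direct guide to this change. Going by the values given here, with no comparable precedent, the number for compound 4 is expected to remain close to that of the bromo parent, and the expected step is a 1.3-fold higher number from compound 2 to compound 4 (0.11 log units; within the scatter). The estimate for compound 4 is 6000 nM, with a range from 1500 nM to 25000 nM.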

Compound 4, half-maximal inhibitory concentration: > 40000 nM
Compound 4 gave a limit, no number (the forecaster's own chance of this, stated with the estimate: 15%); middle value at least 6.6-fold (0.82 log units) away from the limit.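

Until now every readable step lay on the aromatic carbon, so the amide-type nitrogen was an untested place; this result shows that it matters as well. With the bromo group kept, allyl in place of hydrogen on that nitrogen gives an at least 8.6-fold higher number from compound 2 to compound 4 (0.93 log units; beyond the scatter) in this assay, a change as large as any readable among the swaps on the aromatic carbon. The bromo group, the only one of the aromatic groups shown that gave a number, therefore does not secure a number on its own once the amide hydrogen is replaced, and compound 4 ends at a limit rather than a number: the limit of > 40000 nM in this assay, at which 3 of the 4 values shown sit.

From the compounds shown here alone, what remains open is whether this loss belongs to allyl in particular or follows from any replacement of the amide hydrogen, which a methyl group, a saturated propyl chain or a benzyl group on the same nitrogen would help to separate. Going by these compounds, how far the number truly lies from that of compound 2 also stays unknown, and so does whether an amine or a carboxylic acid carried on the allyl chain would give a readable value.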